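Methoxy to hydroxy on compound 3: working notes

The source may hold more compounds than are shown below. What is called first, only, known or untested is meant among the compounds shown, and "the series" means these compounds.

Measured in an ADME assay on L6 cells (Rattus norvegicus) for cytotoxicity (a higher number here means a weaker inhibitor, a lower number a stronger inhibitor), each value a limit:
compound 1 `CC(C)NC(=N)c1ccc(-c2cc3ccc(C(=N)NC(C)C)cc3o2)cc1`: > 199000 nM
compound 2 `CC(C)NC(=N)c1ccc(-c2cc3cc(C(=N)NC(C)C)cc(O)c3o2)c(O)c1`: > 179000 nM
compound 3 `COc1cc(C(=N)NC(C)C)ccc1-c1cc2ccc(C(=N)NC(C)C)cc2o1`: > 181000 nM

Compound 3 stands at the limit > 181000 nM and has no readable number. Compound 4 `CC(C)NC(=N)c1ccc(-c2cc3ccc(C(=N)NC(C)C)cc3o2)c(O)c1` differs from it as hydrogen in place of methyl on an oxygen on an aromatic ring, methoxy to hydroxy. Within the data shown here, the only measured step, a step that the two limits leave unreadable from compound 1 to compound 3, gives no size to carry over. Compound 2, which also carries hydroxy, reads > 179000 nM, again a limit. In this assay no step beyond the scatter is therefore expected, and compound 4 will probably report a limit too. The estimated step is a step that the limit leaves unreadable from compound 3 to compound 4. Compound 4 is estimated at 185000 nM, with an expected range from 60000 nM to 200000 nM.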

Compound 4, half-maximal inhibitory concentration: > 183000 nM
Compound 4 was reported as a limit; the forecaster's own chance of this, stated with the estimate: 80%; the middle value lies beyond the limit too.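

In this assay compound 4 gives > 183000 nM, a limit, so its steps from compound 1 and compound 3 cannot be read. The compounds shown leave open whether hydrogen, methoxy or hydroxy on that aromatic carbon differ at all in this assay.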